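A few compounds are considered here, and "the series" means these few. Any claim that something is new, unique, unknown or untested is made for them only; others in the source may bear on it.

Among the compounds with values here, in a functional assay on HL-60 cells (Homo sapiens) for inhibition, read by MTT assay, with a stated time of 72 h (a higher number here means a weaker inhibitor, a lower number a stronger inhibitor), compound 3 `Cc1nc(-c2cccc(F)c2)c(C(=O)N2CCN(c3cccc(Cl)c3)CC2)o1` gives 33.7 nM, the lowest of the three numbers so far. Compound 2 `Cc1nc(-c2ccccc2)c(C(=O)N2CCN(c3cccc(C)c3C)CC2)o1` gives 35 nM, which lies within the scatter of compound 3, so no order between the two is claimed. Within the data shown here, compound 1 `Cc1nc(-c2cccc(O)c2)c(C(=O)N2CCN(c3cccc(Cl)c3)CC2)o1` gives 105 nM; the only single-place step among the measured compounds, a 3.1-fold lower number from compound 1 to compound 3 (0.49 log units; beyond the scatter), concerns fluoro in place of hydroxy on an aromatic carbon and is therefore of modest size.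

Compound 4 `Cc1nc(-c2ccccc2)c(C(=O)N2CCN(c3cccc(Cl)c3)CC2)o1` differs from compound 3 in one place: hydrogen in place of fluoro on an aromatic carbon. Among the measured compounds shown here, no measured step follows this particular change directly. The step from compound 1 to compound 3 touches the same aromatic carbon but swaps a different group, so it bears on the question only loosely. Compound 2 carries the unsubstituted phenyl, though on a differently substituted amine part, and its value sits within the scatter of compound 3, which suggests that losing the fluoro alone changes little.

Compound 4 is therefore expected to give 42 nM, with a likely range from 20 nM to 90 nM. The expected step of a 1.2-fold higher number from compound 3 to compound 4 (0.10 log units; within the scatter) is estimated to stay within the scatter.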

Compound 4, half-maximal inhibitory concentration: 39.2 nM
Estimate against measurement, compound 4: 1.1-fold (0.03 log units) above; measured number inside the range.
By their numbers in this assay, from the lowest: compounds 3, 2 and 4 (each within the scatter of the next); then compound 1.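

In this assay the change from 3-fluorophenyl to phenyl gives a 1.2-fold higher number from compound 3 to compound 4 (0.07 log units; within the scatter), so fluoro and hydrogen on this aromatic carbon cannot be told apart, while hydroxy stands apart from both, with a 2.7-fold lower number from compound 1 to compound 4 (0.43 log units; beyond the scatter) for hydrogen in its place. With the unsubstituted phenyl kept, a 1.1-fold higher number from compound 2 to compound 4 (0.05 log units; within the scatter) shows that 3-chlorophenyl and 2,3-dimethylphenyl on the amine nitrogen cannot be told apart either. Nothing given here bears on why hydroxy alone stands apart.

Going by these compounds, what a methoxy group, an amine or a carboxylic acid on this aromatic carbon would give remains open. Also open, on these data alone, is whether hydroxy, fluoro and hydrogen would fall in the same order with 2,3-dimethylphenyl on the amine nitrogen.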